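The source may hold more compounds than are shown below. What is called first, only, known or untested is meant among the compounds shown, and "the series" means these compounds.

Measured compounds:
compound 1, `CC(C)(C)[C@H](C(=O)Nc1ncc(F)s1)c1ccc(Cl)cc1`: 700 nM in a functional assay on CHO cells for agonist activity at Free fatty acid receptor 2 (Homo sapiens), read by cAMP accumulation; a higher number here means a weaker inhibitor, a lower number a stronger inhibitor
compound 2, `CC(C)(C)[C@H](C(=O)Nc1ncc(Br)s1)c1ccc(Cl)cc1`: 700 nM in this assay
compound 3, `CSc1cnc(NC(=O)[C@H](c2ccc(Cl)cc2)C(C)(C)C)s1`: 500 nM in this assay

The three numbers sit within the scatter of one another: no change at the digits printed from compound 1 to compound 2 (within the scatter), a 1.4-fold lower number from compound 1 to compound 3 (0.15 log units; within the scatter) and a 1.4-fold lower number from compound 2 to compound 3 (0.15 log units; within the scatter). Compound 3 therefore stands apart from neither of the others. All three differ only at one aromatic carbon of the shared core. Compound 4, `CN(C)c1cnc(NC(=O)[C@H](c2ccc(Cl)cc2)C(C)(C)C)s1`, continues at that carbon: dimethylamino in place of methylsulfanyl on an aromatic carbon. Among the measured compounds shown here, no measured step involves dimethylamino; the steps that bear on it are the three exchanges at the same carbon, none of which went beyond the scatter. The expectation is accordingly no step beyond the scatter, no change at the digits printed from compound 3 to compound 4 (within the scatter). For compound 4 in this assay the estimated value is 500 nM, with a range from 200 nM to 1500 nM.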

Compound 4, half-maximal inhibitory concentration: 1600 nM
Compound 4: the middle estimate sits 3.2-fold (0.51 log units) below what was measured; the whole stated range lies below it.
By their numbers in this assay, from the lowest: compounds 3, 1 and 2 (each within the scatter of the next); then compound 4.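

Fluoro, bromo and methylsulfanyl showed no separation at this carbon, so dimethylamino is the one group of the four that moves the number in this assay (the steps are a 3.2-fold higher number from compound 3 to compound 4 (0.51 log units; beyond the scatter) and a 2.3-fold higher number from compound 2 to compound 4 (0.36 log units; beyond the scatter) and a 2.3-fold higher number from compound 1 to compound 4 (0.36 log units; beyond the scatter)). All three steps run toward a weaker inhibitor, so this position does respond to its substituent, though modestly. (No measurement at hand accounts for the shift). Going by these compounds, whether the change follows the attached nitrogen or its two methyls stays open. An unsubstituted amine or a methoxy group at this carbon would help separate the two.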